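This account rests on a few compounds, and the source may have more. Where it says the series, first, only, none or still open, it means among the compounds named here.

Compound 1 `Cc1ccc(NC2=CC(=O)c3nc4n(c3C2=O)[C@H]2OC[C@@H](O)[C@H]2OC4)cc1` carries a (4-methylphenyl)amino group on the shared core. Among the compounds with values here, in a functional assay on HeLa cells (Homo sapiens) for inhibition, read by sulforhodamine B assay (a lower number here means a stronger inhibitor, a higher number a weaker inhibitor), compound 1 gives 3860 nM, the only number among the values shown. Compound 2 `COc1ccc(NC2=CC(=O)c3c(nc4n3[C@H]3OC[C@@H](O)[C@H]3OC4)C2=O)cc1` sits at that limit of the assay, (the limit of > 8000 nM in this assay, at which 1 of the 2 values shown sits), and in this assay compound 2 gives > 8000 nM. Compound 3 `COc1ccc(NC2=CC(=O)c3nc4n(c3C2=O)[C@H]2OC[C@@H](O)[C@H]2OC4)cc1` differs from compound 1 by methoxy in place of methyl on an aromatic carbon. Within the data shown here, no measured step covers this change, so the step is expected to be a 1.6-fold higher number from compound 1 to compound 3 (0.19 log units; within the scatter), a modest weakening. Compound 3 is expected to give 6000 nM in this assay, somewhere between 2500 nM and 15000 nM.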

Compound 3, half-maximal inhibitory concentration: 4780 nM
Compound 3: the middle estimate sits 1.3-fold (0.10 log units) above what was measured; low and high end bracket the measured number.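

On the aromatic ring of the (4-methylphenyl)amino group, the swap to methoxy is a step of a 1.2-fold higher number from compound 1 to compound 3 (0.09 log units; within the scatter) in this assay, so the two compounds cannot be told apart. At this position, then, a methyl and a methoxy, which brings one hydrogen-bond acceptor, both leave a measured number on the shared core. Nothing shown explains why the two groups read alike.

Going by these compounds, whether an amine, a carboxylic acid or a longer chain on this ring carbon would move the number beyond the scatter remains open.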